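Chloro to Fluoro on the Benzylsulfanyl Arm

The compounds below may be only part of what the source reports. "The series", "measured", "known", "first", "only" and "open" are said of these compounds alone.

Compound 1 `CC1=C(C(=O)Nc2ccc(F)cc2)C(c2ccc([N+](=O)[O-])cc2)N=C(SCc2ccc(Cl)cc2)N1` and compound 2 `CC1=C(C(=O)Nc2ccc(F)cc2)C(c2ccc([N+](=O)[O-])cc2)N=C(SCc2ccc(F)cc2)N1` share one core. In a functional assay on the whole organism (artery, strain albino) with Rattus norvegicus as the target, with a stated time of 180 min, at a dose of 10 mg/kg by the oral route (on this read-out lower numbers stand for less inhibition and higher numbers for more inhibition at the one dose given (going by the name of the read-out)), compound 1 gives 23.2% and compound 2 gives 20.1%; the step of a number 3.1 percentage points lower from compound 1 to compound 2 (within the scatter) belongs to the change (fluoro in place of chloro on an aromatic carbon). Compound 3 `CC1=C(C(=O)Nc2ccc([N+](=O)[O-])cc2)C(c2cccc([N+](=O)[O-])c2)N=C(SCc2ccc(Cl)cc2)N1` rests on a different core, and how the two cores differ is not broken down here. In this assay compound 3 gives 14.9%, which sits within the scatter of the two earlier numbers. Compound 4 `CC1=C(C(=O)Nc2ccc([N+](=O)[O-])cc2)C(c2cccc([N+](=O)[O-])c2)N=C(SCc2ccc(F)cc2)N1` is obtained from compound 3 by fluoro in place of chloro on an aromatic carbon, the same change, at a place described in the same words, as from compound 1 to compound 2. Because that earlier step a number 3.1 percentage points lower from compound 1 to compound 2 (within the scatter) stayed within the scatter, a step of a number 2.9 percentage points lower from compound 3 to compound 4 (within the scatter) is expected here. Compound 4 is therefore estimated at 12% in this assay, expected between 4% and 21%.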

Compound 4, a percentage reported as inhibition, in the whole organism at one dose (the size of the read-out at that dose, not a potency): 17.5%
The estimate for compound 4 lay 5.5 percentage points below the measured number; measured number inside the range.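

The change from (4-chlorobenzyl)sulfanyl to (4-fluorobenzyl)sulfanyl gives a number 2.6 percentage points higher from compound 3 to compound 4 (within the scatter) in this assay. Set beside the earlier step, the two cores do not separate: the same change on two cores in this assay, a number 3.1 percentage points lower (within the scatter) from compound 1 to compound 2 and a number 2.6 percentage points higher (within the scatter) from compound 3 to compound 4, 5.7 percentage points apart, within the scatter of two such steps. On these two cores the change thus carries over without a step beyond the scatter, but the two pairs give it no direction and set no rule for other cores.

Open, on these data alone, is what a group other than chloro or fluoro would give on the benzyl ring, such as methoxy, trifluoromethyl, an amine or a carboxylic acid. Also open, as far as these compounds go, is whether the same change reads alike at another dose.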